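Heteroaromatic Replacement on a Potent Cyclic Sulfonamide

A few compounds are considered here, and "the series" means these few. Any claim that something is new, unique, unknown or untested is made for them only; others in the source may bear on it.

The three measured compounds share a core in which a piperazine-bearing benzoxazine carries an arylsulfonyl group on its ring nitrogen. In an assay on HEK293 cells for displacement of a labelled ligand from 5-hydroxytryptamine receptor 6 (Homo sapiens) (a lower number here means a stronger inhibitor, a higher number a weaker inhibitor), compound 1 `CS(=O)(=O)Nc1cccc(S(=O)(=O)N2CCOc3c(N4CCNCC4)cccc32)c1` gives 200 nM, and compound 2 `CS(=O)(=O)c1ccccc1S(=O)(=O)N1CCOc2c(N3CCNCC3)cccc21` gives 316 nM. Compound 3 `O=S(=O)(c1cccc2ccccc12)N1CCOc2c(N3CCNCC3)cc(Cl)cc21` stands apart: in this assay compound 3 gives 0.794 nM, the lowest of the three numbers, and its distance from compound 1 and from compound 2 lies well beyond the scatter of repeated measurements.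

Compound 4 `O=S(=O)(c1cccc2nonc12)N1CCOc2c(N3CCNCC3)cc(Cl)cc21` is not yet measured. It differs from compound 3 in one place: a group of 9 heavy atoms (6 carbon, 2 nitrogen, 1 oxygen; one five-membered aromatic ring with 3 hetero atoms, one six-membered aromatic ring of carbon only) in place of a group of 10 heavy atoms (10 carbon; 2 six-membered aromatic rings of carbon only), on a sulfonyl sulfur. Going by the values given here, no measured pair shows this exact exchange, so the size of the step cannot be read from the data. Because compound 3 gives 0.794 nM and the exchange keeps the bicyclic aromatic shape while altering its atoms, a modest weakening is expected, a step of a 3.1-fold higher number from compound 3 to compound 4 (0.50 log units; beyond the scatter) that probably exceeds the scatter but stays well short of the gap to compound 1. Compound 4 is estimated at 2.5 nM in this assay, with a range from 0.8 nM to 8 nM.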

Compound 4, inhibition constant: 0.501 nM
Beside the measured number, compound 4's estimate is 5.0-fold (0.70 log units) above it; the whole stated range lies above it.
By their numbers in this assay, from the lowest: compounds 4 and 3 (each within the scatter of the next); then compounds 1 and 2 (each within the scatter of the next).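

Among the compounds shown, compound 3 and compound 4 form the first pair that differs in one place, so this is the first direct reading of the group on a sulfonyl sulfur whose other neighbour is the sulfonamide nitrogen in a ring. In this assay, the step of a 1.6-fold lower number from compound 3 to compound 4 (0.20 log units; within the scatter) lies within the scatter, so naphthalen-1-yl and a group with a five-membered aromatic ring holding 3 hetero atoms and 3 hydrogen-bond acceptors cannot be told apart here. No measured evidence accounts for this result.

The shown compounds leave open whether other bicyclic groups, such as quinoline or indole, or a single phenyl ring would read the same at this sulfur. They also leave open whether the same exchange would hold on a core without the chlorine.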